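The compounds below may be only part of what the source reports. "The series", "measured", "known", "first", "only" and "open" are said of these compounds alone.

Three compounds of the series have been run in a functional assay on HeLa cells (Homo sapiens) for cytotoxicity; a lower number here means a stronger inhibitor, a higher number a weaker inhibitor. Compound 1 `Nc1[nH]nc2nnc(-c3ccccc3-c3ccccc3)c(-c3ccccc3-c3ccccc3)c12` gives 30700 nM in this assay and is the only one of the three with a measured number. Compound 2 `Nc1ccc(-c2[nH]nc3nnc(N)c-3c2-c2ccc(N)cc2)cc1` returns only a limit of the assay in this assay, > 100000 nM. Compound 3 `Nc1nn(COCCO)c2nnc(-c3ccccc3)c(-c3ccccc3)c12` likewise returns only a limit of the assay in this assay, > 100000 nM. Compound 3 thus stands at the weak end of what the numbers show, the position described by the limit of > 100000 nM in this assay, at which 2 of the 3 values shown sit, and where it lies beyond that point is not known.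

Compound 4 `Nc1nn(CCOCCO)c2nnc(-c3ccccc3)c(-c3ccccc3)c12` is next to be measured in this assay. It differs from compound 3 by (2-hydroxyethoxy)methyl in place of 2-hydroxyethoxy on a saturated chain carbon bound to an aromatic nitrogen. Going by the values given here, no step between measured compounds touches this part of the molecule, so nothing measured tells how a longer chain at this place shifts the read-out; the expectation rests on the standing of compound 3 at the limit. The step of a number no higher from compound 3 to compound 4 (the limit leaves the size open) is expected to be none beyond the scatter, with the most likely outcome that the assay again reports only a limit. Compound 4 is estimated at 100000 nM, in the range from 30000 nM to 300000 nM.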

Compound 4, half-maximal inhibitory concentration: > 100000 nM
Compound 4: no number, only a limit; the forecaster's own chance of this, stated with the estimate: 80%; the middle value sits exactly at the limit.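

In this assay compound 4 gives > 100000 nM as a limit of the assay and not a number. Going by these compounds alone, compound 3 likewise gives > 100000 nM as a limit, so no step between the two can be read. The compounds shown leave open whether (2-hydroxyethoxy)methyl in place of 2-hydroxyethoxy shifts the read-out in this assay at all.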